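Trading a chloro for hydrogen in compound 2

This account rests on a few compounds, and the source may have more. Where it says the series, first, only, none or still open, it means among the compounds named here.

Compound 1 `Cc1ccsc1/C=C(/SCc1ccc(Cl)cc1)C(=O)c1ccc(Cl)cc1` gives 50000 nM
Compound 2 `COc1ccccc1/C=C(\C(=O)c1ccc(Cl)cc1)S(=O)(=O)Cc1ccc(Cl)c(Cl)c1` gives 1000 nM
Compound 3 `Cc1ccc(S/C(=C/c2ccc(N(C)C)cc2)C(=O)c2ccc(Cl)cc2)cc1` gives > 100000 nM (a limit)

In a functional assay on DU-145 cells (Homo sapiens) for inhibition, read by trypan blue exclusion, with a stated time of 96 h (on this read-out lower numbers stand for stronger inhibition of growth and higher numbers for weaker inhibition of growth), compound 2 has the lower of the two actual numbers, with 1000 nM as its value. Compound 1 gives 50000 nM and the gap is beyond the usual scatter. For compound 3 the assay reports only a limit, > 100000 nM and no number.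

The next compound is compound 4 `COc1ccccc1/C=C(\C(=O)c1ccc(Cl)cc1)S(=O)(=O)Cc1ccc(Cl)cc1` which differs from compound 2 in one place: hydrogen in place of chloro on an aromatic carbon. The 3,4-dichlorobenzyl group thus becomes 4-chlorobenzyl. Going by the values given here, no measured pair here shows this change, so the expectation starts from compound 2 and its 1000 nM reading.

A modest move towards weaker growth inhibition in this assay is expected, close to the edge of the scatter. The estimated 2.0-fold higher number from compound 2 to compound 4 (0.30 log units; within the scatter) would be a small rise in the number. Compound 4 is expected at 2000 nM (estimated range 400 nM to 10000 nM)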

Compound 4, concentration for 50% growth inhibition: 25000 nM
Estimate against measurement, compound 4: 13-fold (1.10 log units) below, and the stated range ends below it.
By their numbers in this assay, from the lowest: compound 2; then compounds 4 and 1 (each within the scatter of the next). At a limit, above all of these: compound 3.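

The change from 3,4-dichlorobenzyl to 4-chlorobenzyl gives a 25-fold higher number from compound 2 to compound 4 (1.40 log units; beyond the scatter) in this assay and so shows that this one chloro, ortho to a chloro group, counts for much of the growth inhibition seen with compound 2. Compounds 1 and 3 could not show this, since each differs from compound 2 in more than one place, whereas this pair isolates a single position on the aromatic ring. Nothing given here explains why the loss of one chlorine atom has so large an effect.

Going by these compounds, it remains open whether chlorine itself matters at this position, or whether another group, such as fluoro, bromo, methyl or nitrile, would serve as well. On these data alone, it is also open whether a step of this size would recur on a different core, such as that of compound 1.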